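Swapping the Amine Arm for an Amide on a Shared Ring

A few compounds are considered here, and "the series" means these few. Any claim that something is new, unique, unknown or untested is made for them only; others in the source may bear on it.

Compound 1 `CC(=O)OC/C1=C/C[C@](C)(CCC=C(C)C)/C=C/[C@@H](OC(=O)C=C(C)C)[C@](C)(OC(C)=O)/C=C/C1=O` and compound 2 `CC(C)=CCC[C@]1(C)/C=C/[C@@H](OC(=O)C=C(C)C)[C@](C)(O)/C=C/C(=O)/C(CN(C(C)C)C(C)C)=C\C1` share a common core. In a functional assay on SMMC-7721 cells (Homo sapiens) for antiproliferative activity, read by MTT assay, with a stated time of 48 h (a higher number here means a weaker inhibitor, a lower number a stronger inhibitor), compound 1 gives 4130 nM, while compound 2 gives 340 nM. Compound 2 therefore holds the lowest of the two numbers, and its gap to compound 1 lies beyond the usual scatter of repeated measurements.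

Compound 3 `CC(C)=CCC[C@]1(C)/C=C/[C@@H](OC(=O)C=C(C)C)[C@](C)(O)/C=C/C(=O)/C(C(=O)N(C)C)=C\C1` differs from compound 2 in one place: dimethylcarbamoyl in place of (diisopropylamino)methyl on a double-bonded ring carbon. Among the measured compounds shown here, no pair of measured compounds shows this change, so its effect is not known from the data. Because compound 2 gives 340 nM with the (diisopropylamino)methyl group in place, losing that group is treated as the main uncertainty. The step of a 2.4-fold higher number from compound 2 to compound 3 (0.37 log units; beyond the scatter) is expected to be modest and toward a higher number, possibly within the scatter. Compound 3 is estimated at 800 nM, with a range from 250 nM to 2500 nM.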

Compound 3, half-maximal inhibitory concentration: 3670 nM
Estimate against measurement, compound 3: 4.6-fold (0.66 log units) below, and the stated range ends below it.
By their numbers in this assay, from the lowest: compound 2; then compounds 3 and 1 (each within the scatter of the next).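

In this assay, exchanging (diisopropylamino)methyl for dimethylcarbamoyl on this double-bonded ring carbon gives an 11-fold higher number from compound 2 to compound 3 (1.03 log units; beyond the scatter), so this position is sensitive to the group it carries and this change is a large one. The two groups have the same counts of hydrogen-bond donors and acceptors, so those counts do not separate them. Nothing at hand explains the size of the step.

The compounds shown leave open whether the step follows the change from amine to amide or the change from isopropyl to methyl groups on the nitrogen, a question that a dimethylaminomethyl group at this carbon could address. As far as these compounds go, how a piperidin-1-ylmethyl group or a carboxylic acid at the same carbon would read also remains open.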